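This account rests on a few compounds, and the source may have more. Where it says the series, first, only, none or still open, it means among the compounds named here.

Of the compounds shown here, three have been measured in an assay for inhibition of Nicotinamide phosphoribosyltransferase (Homo sapiens), read by mass spectrometry, with stated times of 15 min and 30 min; on this read-out lower numbers stand for stronger inhibition and higher numbers for weaker inhibition. Compound 1 `O=C(NCc1ccc(S(=O)(=O)c2ccccc2)cc1)c1ccc2nncn2c1` gives 370 nM in this assay, and compound 2 `O=C(NCc1ccc(S(=O)(=O)c2ccccc2)cc1)c1cn2ccnc2cn1` gives 150 nM. Compound 3 `O=C(NCc1ccc(S(=O)(=O)N2CCCCC2)cc1)c1ccc2nc[nH]c2c1`, which differs from both of them in several places, gives 310 nM. Of the three numbers, compound 2 stands lowest: compound 3 sits nearer to it, compound 1 furthest, and both gaps lie beyond the scatter. Among the measured compounds shown here, the one step that joins two compounds differing in a single place is a 2.5-fold lower number from compound 1 to compound 2 (0.39 log units; beyond the scatter), a modest change produced by exchanging one aromatic amide group for another on the carbonyl carbon.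

Compound 4 `O=C(NCc1ccc(S(=O)(=O)c2ccccc2)cc1)c1nc2ccncc2s1` has not yet been measured. It differs from compound 2 by a group of 9 heavy atoms (6 carbon, 2 nitrogen, 1 sulfur; one five-membered aromatic ring with 2 hetero atoms, one six-membered aromatic ring with 1 hetero atom) in place of a group of 9 heavy atoms (6 carbon, 3 nitrogen; one five-membered aromatic ring with 2 hetero atoms, one six-membered aromatic ring with 2 hetero atoms), on a carbonyl carbon. For the measured compounds named here, the step from compound 1 to compound 2 is the only measured change of the same kind, an exchange of one aromatic group on the carbonyl carbon for another, and it moved the number by a modest amount. With no further guide, a step of similar size at most is expected, and since compound 2 already holds the lowest number, the more likely direction is toward a higher number. Compound 4 is therefore expected to give 260 nM, within a range from 100 nM to 700 nM, which would mean an estimated step of a 1.7-fold higher number from compound 2 to compound 4 (0.24 log units; within the scatter).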

Compound 4, half-maximal inhibitory concentration: 210 nM
Compound 4: the middle estimate sits 1.2-fold (0.09 log units) above what was measured; low and high end bracket the measured number.
By their numbers in this assay, from the lowest: compounds 2, 4, 3 and 1 (each within the scatter of the next, the first and the last beyond it).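

In this assay, the group with 6 carbon, 2 nitrogen and 1 sulfur atoms on the carbonyl carbon gives a 1.4-fold higher number from compound 2 to compound 4 (0.15 log units; within the scatter), and set against the group in compound 1 it gives a 1.8-fold lower number from compound 1 to compound 4 (0.25 log units; within the scatter). Both steps lie within the scatter, so compound 4 cannot be told apart from either neighbour, even though the two neighbours are themselves separated by a 2.5-fold lower number from compound 1 to compound 2 (0.39 log units; beyond the scatter). This place therefore accepts a sulfur-bearing group with one six-membered aromatic ring with 1 hetero atom without any clear loss or gain against compound 2, which shows that the exchanged group need not be all carbon and nitrogen, and nothing shown gives a reason for these numbers.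

The entry of sulfur and the change in the hetero atoms of the six-membered ring happen in one step, so the compounds shown cannot separate the two. They also leave open how this place would respond to a group outside the fused aromatic pairs seen so far, such as a single phenyl ring, or to one of these groups carrying an amine or a carboxylic acid.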